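The source may hold more compounds than are shown below. What is called first, only, known or untested is meant among the compounds shown, and "the series" means these compounds.

Working notes on the series, all read in a functional assay on K562 cells (Homo sapiens) for antiproliferative activity, with a stated time of 72 h; on this read-out higher numbers stand for weaker inhibition and lower numbers for stronger inhibition. Compound 1 `OC[C@H]1O[C@@H](n2cnc3c(NCc4ccc(F)cc4)ncnc32)[C@H](O)[C@@H]1O` gives 2700 nM. Compound 2 `COc1cccc(CNc2ncnc3c2ncn3[C@@H]2O[C@H](CO)[C@@H](O)[C@H]2O)c1OC` gives > 166000 nM, which is a limit of the assay and not a number. Compound 3 `Cc1cccc(CNc2ncnc3c2ncn3[C@@H]2O[C@H](CO)[C@@H](O)[C@H]2O)c1O` gives 18000 nM, the higher of the two true numbers in the set, with compound 1 as its nearest neighbour.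

Compound 4 `OC[C@H]1O[C@@H](n2cnc3c(NCc4cccc(C(F)(F)F)c4)ncnc32)[C@H](O)[C@@H]1O` carries 3-(trifluoromethyl)phenyl in place of 2-hydroxy-3-methylphenyl on a saturated chain carbon bound to a nitrogen on an aromatic ring.

All three measured steps change this same group. The closest guide is a 6.7-fold higher number from compound 1 to compound 3 (0.82 log units; beyond the scatter), since compound 4, like compound 1, has a fluorine-bearing phenyl and no hydroxyl. Wider swings also occur here, as an at least 61-fold higher number from compound 1 to compound 2 (1.78 log units; beyond the scatter) and an at least 9.2-fold lower number from compound 2 to compound 3 (0.96 log units; beyond the scatter) show, so the range stays broad. A modest step to a lower number is therefore expected in this assay, probably not passing far beyond compound 1. The expected step is a 3.0-fold lower number from compound 3 to compound 4 (0.48 log units; beyond the scatter). The estimate for compound 4 is 6000 nM, within a range of 1500 nM to 25000 nM.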

Compound 4, half-maximal inhibitory concentration: > 166000 nM
Compound 4 was reported as a limit; the forecaster's own chance of this, stated with the estimate: 5%; at least 27-fold (1.44 log units) between middle value and limit.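

In this assay, 3-(trifluoromethyl)phenyl on a saturated chain carbon bound to a nitrogen on an aromatic ring gives an at least 9.2-fold higher number from compound 3 to compound 4 (0.96 log units; beyond the scatter) and an at least 61-fold higher number from compound 1 to compound 4 (1.78 log units; beyond the scatter). Compound 4 gives a limit of the assay and not a number, the second such limit in the series: the limit of > 166000 nM in this assay, at which 2 of the 4 values shown sit. A fluorine-bearing phenyl therefore does not by itself preserve a measurable number, with compound 1 going against compound 4, and reaching the limit is no longer confined to the dimethoxy group of compound 2.

The step from compound 2 to compound 4 cannot be read, since both values are limits. Open, from the compounds shown here alone, is whether 4-(trifluoromethyl)phenyl, or a phenyl carrying an amine or a carboxylic acid, would give a number in this assay on the same core.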